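An Acid in Place of a Tertiary Amide on One Core

This account rests on a few compounds, and the source may have more. Where it says the series, first, only, none or still open, it means among the compounds named here.

Compound 1 `C=CCN(C)C(=O)c1ccc(C(CC)(CC)c2ccc(OCCC(O)(CC)CC)c(C)c2)n1CC`: 12800 nM
Compound 2 `C#CC(C)OC(=O)c1ccc(C(CC)(CC)c2ccc(OCCC(O)(CC)CC)c(C)c2)n1CC`: 14800 nM
Compound 3 `CCOc1ccc(NC(=O)c2ccc(C(CC)(CC)c3ccc(OCCC(O)(CC)CC)c(C)c3)n2CC)cc1`: > 50000 nM

Three compounds sharing one core were tested in a functional assay on PC-3 cells (Homo sapiens) for antiproliferative activity, read by MTT assay, with a stated time of 48 h; on this read-out lower numbers stand for stronger inhibition and higher numbers for weaker inhibition. Compound 1 gives 12800 nM, the lowest of the two numbers shown. Compound 2 sits close to it, with a 1.2-fold higher number from compound 1 to compound 2 (0.06 log units; within the scatter). For compound 3 the assay reports only a limit, > 50000 nM, not a number. That corresponds to an at least 3.9-fold higher number from compound 1 to compound 3 (0.59 log units; beyond the scatter) and an at least 3.3-fold higher number from compound 2 to compound 3 (0.52 log units; beyond the scatter).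

Compound 4 `CCn1c(C(=O)NC(C)C(=O)O)ccc1C(CC)(CC)c1ccc(OCCC(O)(CC)CC)c(C)c1` has not yet been measured in this assay. It differs from compound 1 in one place: (1-carboxyethyl)amino in place of allyl(methyl)amino on a carbonyl carbon. Going by the values given here, the steps that bear on this are those from compound 1 to compound 2 and from compound 1 to compound 3, both changing the same group on the carbonyl carbon; one stayed within the scatter, the other weakened the compound at least modestly. Neither introduces a carboxylic acid, so the expected direction rests on thin ground. A step of a 1.6-fold higher number from compound 1 to compound 4 (0.19 log units; within the scatter) towards weaker inhibition is expected for compound 4. Compound 4 is therefore estimated at 20000 nM, within a range from 7000 nM to 55000 nM.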

Compound 4, half-maximal inhibitory concentration: 11700 nM
Estimate against measurement, compound 4: 1.7-fold (0.23 log units) above, within the range that was stated.
By their numbers in this assay, from the lowest: compounds 4, 1 and 2 (each within the scatter of the next). At a limit, above all of these: compound 3.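

In this assay, a free carboxylic acid is tolerated on this carbonyl carbon: (1-carboxyethyl)amino enters with a 1.1-fold lower number from compound 1 to compound 4 (0.04 log units; within the scatter) and with a 1.3-fold lower number from compound 2 to compound 4 (0.10 log units; within the scatter). Exchanging only the group on the amide-type nitrogen, 1-carboxyethyl for 4-ethoxyphenyl, gives an at least 4.2-fold lower number from compound 3 to compound 4 (0.63 log units; beyond the scatter), so an amide-type nitrogen that keeps its hydrogen does not by itself go with weak inhibition. Compound 3 carries a limit of the assay and not a number: the limit of > 50000 nM in this assay, at which 1 of the 4 values shown sits.

The compounds shown leave open what the methyl ester of this acid, or a longer chain carrying the carboxylic acid, would give on this read-out. Also open, from the compounds shown here alone, is whether any group on this carbonyl carbon can give clearly stronger inhibition than compound 4 does.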